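Dithiocarbamates on SK-BR-3 cells: pyrrole to methylisoxazole

The source may report more compounds than this note shows. Statements on the series, on what has been measured and on what is new or still open speak of the compounds shown alone.

Three compounds have been measured in a functional assay on SK-BR-3 cells (Homo sapiens) for cytotoxicity, read by resazurin assay, with a stated time of 72 h; on this read-out lower numbers stand for stronger inhibition and higher numbers for weaker inhibition:
compound 1, `CC1(C)OB(CCCSC(=S)NCc2cccnc2)OC1(C)C`, gives 6820 nM
compound 2, `S=C(NCc1cccnc1)SCCc1nnn[nH]1`, gives > 100000 nM
compound 3, `S=C(NCc1cccnc1)SCCc1nnc(-c2cc[nH]c2)o1`, gives 820 nM

Among the compounds with values here, compound 3 stands lowest of the two numbers known, and compound 1 sits beyond the usual scatter from it. The entry for compound 2 is not a number but a limit of the assay (the limit of > 100000 nM in this assay, at which 1 of the 3 values shown sits).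

Compound 4, `Cc1cc(-c2nnc(CCSC(=S)NCc3cccnc3)o2)no1`, is not yet measured and differs from compound 3 in one place: 5-methyl-1,2-oxazol-3-yl in place of 1H-pyrrol-3-yl on an aromatic carbon. Within the data shown here, no measured pair shows a change of this kind, so its size is unknown. A small shift toward a higher number, a 1.8-fold higher number from compound 3 to compound 4 (0.26 log units; within the scatter), is expected, within or close to the scatter. Compound 4 is estimated at 1500 nM, with a range from 400 nM to 6000 nM.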

Compound 4, half-maximal inhibitory concentration: 1730 nM
Compound 4: middle estimate off by 1.2-fold (0.06 log units), on the low side; low and high end bracket the measured number.
By their numbers in this assay, from the lowest: compound 3; then compound 4; then compound 1. At a limit, above all of these: compound 2.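

In this assay, this aromatic carbon takes a second ring swap at only a modest cost: 5-methyl-1,2-oxazol-3-yl in place of 1H-pyrrol-3-yl gives a 2.1-fold higher number from compound 3 to compound 4 (0.32 log units; beyond the scatter), a step just beyond the scatter. The entering group has 0 hydrogen-bond donors, yet compound 4 still reads 1730 nM. Nothing measured here accounts for the size of this step.

As far as these compounds go, whether a plain phenyl ring or a small amine at this carbon would lower or raise the number stays open. So does the share of the methyl in 5-methyl-1,2-oxazol-3-yl on its own.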